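The compounds below may be only part of what the source reports. "The series", "measured", "known", "first", "only" and "open" are said of these compounds alone.

Of the compounds shown here, two have so far been measured in an assay on HEK293 cells for displacement of a labelled ligand from Type-2 angiotensin II receptor (Homo sapiens), read by scintillation counting, with a stated time of 240 min; on this read-out higher numbers stand for weaker inhibition and lower numbers for stronger inhibition. Compound 1 `COC(=O)NS(=O)(=O)c1sc(CC(C)C)cc1-c1cccc(Cn2ccnc2)c1` gives 400 nM, while compound 2 `CC(C)Cc1cc(-c2cccc(Cn3ccnc3)c2)c(S(=O)(=O)NC(=O)OCC2CC2)s1` gives 140 nM. Going by the values given here, the single step between them is a 2.9-fold lower number from compound 1 to compound 2 (0.46 log units; beyond the scatter), a change at the far end of the group attached through oxygen to the carbonyl. Among the compounds with values here, on the two numbers available, compound 2 stands as the lower of the pair, with compound 1 as its only neighbour.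

Compound 3 `CCCCCC(=O)NS(=O)(=O)c1sc(CC(C)C)cc1-c1cccc(Cn2ccnc2)c1` has not yet been measured. It differs from compound 2 in one place: pentyl in place of cyclopropylmethoxy on a carbonyl carbon. The change sits on the carbonyl carbon whose other neighbour is the amide-type nitrogen, so the whole cyclopropylmethoxy group is removed and a pentyl chain takes its place.

Within the data shown here, no measured step speaks directly to this change. Among the measured compounds shown here, the one step known, a 2.9-fold lower number from compound 1 to compound 2 (0.46 log units; beyond the scatter), altered only the tip of the group that is now replaced, and says nothing about exchanging it entirely. The expectation for compound 3 is therefore a number close to that of compound 2, with a modest drift toward weaker inhibition allowed for. Compound 3 is estimated at 220 nM, with a range from 60 nM to 800 nM. That estimate means an expected step of a 1.6-fold higher number from compound 2 to compound 3 (0.20 log units; within the scatter).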

Compound 3, inhibition constant: 280 nM
For compound 3 the middle estimate is 1.3-fold (0.10 log units) below the measured one; low and high end bracket the measured number.
By their numbers in this assay, from the lowest: compounds 2, 3 and 1 (each within the scatter of the next, the first and the last beyond it).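

In this assay, the exchange of cyclopropylmethoxy for pentyl on a carbonyl carbon gives a 2.0-fold higher number from compound 2 to compound 3 (0.30 log units; within the scatter) and so replaces the whole group, including its oxygen and its ring, without a difference that stands clear of the scatter. Pentyl in place of methoxy at the same carbonyl carbon gives a 1.4-fold lower number from compound 1 to compound 3 (0.15 log units; within the scatter) and also stays within the scatter, so compound 3 cannot be separated from either neighbour, even though compound 1 and compound 2 are separated by a 2.9-fold lower number from compound 1 to compound 2 (0.46 log units; beyond the scatter) and lie beyond the scatter of each other. No measurement is available that would explain these results.

Compound 3 loses the oxygen and the ring of compound 2 in a single change, so the part played by each one alone remains unresolved. On these data alone, how far this position accepts other groups also remains open, for example a shorter chain such as propyl, a longer chain such as octyl, or a pentyl chain ending in an amine or a carboxylic acid.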